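This account rests on a few compounds, and the source may have more. Where it says the series, first, only, none or still open, it means among the compounds named here.

Compound 1 `CCOC(=O)C1=C(C)NC(=O)NC1c1ccc(O)c(O)c1`: 1.6 ug/mL
Compound 2 `CCOC(=O)C1=C(C)NC(=S)NC1c1ccc(SC)cc1`: 8.5 ug/mL
Compound 3 `CCOC(=O)C1=C(C)NC(=O)NC1c1ccc(SC)cc1`: 10 ug/mL

Three compounds sharing one core were tested in a functional assay on OVCAR-3 cells (Homo sapiens) for inhibition, read by sulforhodamine B assay, with a stated time of 48 h; a lower number here means a stronger inhibitor of growth, a higher number a weaker inhibitor of growth. Compound 2 stands at the second highest number of the three. Its nearest neighbour is compound 3, whose value of 10 ug/mL lies within the usual scatter of compound 2, so the two cannot be told apart. Compound 1, with a value of 1.6 ug/mL, stands clearly lower, beyond the scatter.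

Compound 4 `CCOC(=O)C1=C(C)NC(=S)NC1c1ccc(F)cc1` differs from compound 2 by fluoro in place of methylsulfanyl on an aromatic carbon. Among the measured compounds shown here, no measured pair shows this change, so its effect cannot be read from any measured step. In this assay the step of a 1.2-fold higher number from compound 2 to compound 4 (0.07 log units; within the scatter) is expected to be small, toward a slightly higher number, and not beyond the scatter. Compound 4 is therefore estimated at 10 ug/mL, within a range from 4 ug/mL to 25 ug/mL.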

Compound 4, concentration for 50% growth inhibition: 24.7 ug/mL
The estimate for compound 4 lay 2.5-fold (0.39 log units) below the measured number, within the range that was stated.
By their numbers in this assay, from the lowest: compound 1; then compounds 2 and 3 (each within the scatter of the next); then compound 4.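

Among the compounds shown here, this is the first measured step, and it shows that the group on this aromatic carbon matters: fluoro in place of methylsulfanyl gives a 2.9-fold higher number from compound 2 to compound 4 (0.46 log units; beyond the scatter) and so a weaker inhibitor of growth. The step is modest, yet it shows that this position is not indifferent to the change. Nothing available explains why the number rises.

This single pair cannot show whether methylsulfanyl itself is favoured or fluoro disfavoured. From the compounds shown here alone, how a longer chain such as ethylsulfanyl, an amine or a carboxylic acid would behave at this position remains open.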